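Chain Extension in Arylpropanoic Acid Lipoxygenase Inhibitors

The source may report more compounds than this note shows. Statements on the series, on what has been measured and on what is new or still open speak of the compounds shown alone.

The study examines three measured compounds and one not yet measured in an assay on isolated protein for inhibition of Arachidonate 12-lipoxygenase (Sus scrofa); on this read-out higher numbers stand for weaker inhibition and lower numbers for stronger inhibition. Compound 1 `CCCCCCCCCCC#CCOCc1cccc(CCC(=O)O)c1` gives 320 nM in this assay. Compound 2 `CCCCCCC#CCOCc1cccc(CCC(=O)O)c1` reaches only the limit of the assay, > 10000 nM in this assay. Compound 3 `CCCCCCCCC#CCOCc1ccc(CCC(=O)O)cc1` gives 100 nM in this assay. The change butyl in place of hydrogen on a saturated chain carbon, six bonds along the chain from a triple-bonded carbon produced an at least 31-fold lower number from compound 2 to compound 1 (1.49 log units; beyond the scatter), a step whose size is known only as a bound because of the limit of > 10000 nM in this assay, at which 1 of the 3 values shown sits. The difference between the core of compound 2 and the core of compound 3 is not broken down here. Compound 4 `CCCCCCCCCCCCC#CCOCc1ccc(CCC(=O)O)cc1` carries the same kind of change, (butyl in place of hydrogen on a saturated chain carbon, eight bonds along the chain from a triple-bonded carbon), though its place is eight rather than six bonds along the chain from a triple-bonded carbon. Compound 4 is expected to show a 2.0-fold lower number from compound 3 to compound 4 (0.30 log units; within the scatter), a smaller step than the earlier one, since compound 3 already gives 100 nM. Compound 4 is therefore estimated at 50 nM, between 15 nM and 200 nM.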

Compound 4, half-maximal inhibitory concentration: 320 nM
Compound 4: middle estimate off by 6.4-fold (0.81 log units), on the low side; the measured number lies above the stated range.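

In this assay, the butyl change gave a 3.2-fold higher number from compound 3 to compound 4 (0.51 log units; beyond the scatter), so the lower number seen on the other core did not carry over, and the direction reversed: the same change on two cores in this assay, an at least 31-fold lower number (1.49 log units; beyond the scatter) from compound 2 to compound 1 and a 3.2-fold higher number (0.51 log units; beyond the scatter) from compound 3 to compound 4, at least 100-fold (2.00 log units) apart, beyond the scatter of two such steps. The size of the earlier step is known only as a bound: the limit of > 10000 nM in this assay, at which 1 of the 4 values shown sits. The two steps differ in core and also in place, six against eight bonds along the chain from a triple-bonded carbon, so the compounds shown do not tell whether the core, the place or both set the outcome.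

On these data alone, it remains open how a longer chain on the core of compound 1 would read. Also open, as far as these compounds go, is how an amide in place of the carboxylic acid would read on either core.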